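Ring-fused lactams: effect of removing the N-aryl group

The compounds below may be only part of what the source reports. "The series", "measured", "known", "first", "only" and "open" are said of these compounds alone.

Measured compounds in a functional assay on HeLa cells (Homo sapiens) for antiproliferative activity, read by MTT assay, with a stated time of 72 h; on this read-out lower numbers stand for stronger inhibition and higher numbers for weaker inhibition:
Compound 1, `COc1ncc(-c2ccc3c(c2)NC(=O)CO3)cc1NS(=O)(=O)c1ccc(F)cc1`: compound 1 gives 7110 nM.
Compound 2, `COc1ncc(-c2ccc3c(c2)N(c2ccc(F)cc2)C(=O)CO3)cc1NS(=O)(=O)c1ccc(F)cc1`: compound 2 gives 10500 nM.
Compound 3, `O=C1COc2ccc(-c3cnc4ccccc4c3)cc2N1c1ccc(F)cc1`: compound 3 gives 38800 nM.

Compounds 1 and 2 share one core; compound 3 carries a different one, and the difference between the two cores is not broken down here. Compound 3 stands highest of the three numbers; its gaps to compound 2 and to compound 1 both lie beyond the scatter.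

The step from compound 2 to compound 1 is hydrogen in place of 4-fluorophenyl on an amide-type nitrogen in a ring, and in this assay it made a 1.5-fold lower number from compound 2 to compound 1 (0.17 log units; within the scatter), a step within the scatter. The same change, at the same place, carries compound 3 to compound 4, `O=C1COc2ccc(-c3cnc4ccccc4c3)cc2N1`: hydrogen in place of 4-fluorophenyl on an amide-type nitrogen in a ring.

Going by the values given here, since the one measured instance of this change, from compound 2 to compound 1, moved the number only within the scatter, the expectation for compound 4 rests on compound 3 staying roughly where it is, with a step of about a 1.4-fold lower number from compound 3 to compound 4 (0.14 log units; within the scatter) expected in this assay. Compound 4 is therefore estimated at 28000 nM, within the range 12000 nM to 70000 nM.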

Compound 4, half-maximal inhibitory concentration: > 40000 nM
Compound 4 was reported as a limit; the forecaster's own chance of this, stated with the estimate: 15%; middle value at least 1.4-fold (0.15 log units) away from the limit.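

In this assay compound 4 gives > 40000 nM, and this is a limit of the assay, not a number. On these data alone, the step can therefore be read only as a floor, an at least 1.0-fold higher number from compound 3 to compound 4 (0.01 log units; that floor lies within the scatter), and the true size and direction of the change on this core stay unknown beyond that floor. The data show no conflict between the two cores, but they do not show that hydrogen in place of 4-fluorophenyl carries over from one core to the other: the same change on two cores in this assay, a 1.5-fold lower number (0.17 log units; within the scatter) from compound 2 to compound 1 and an at least 1.0-fold higher number (0.01 log units; that floor lies within the scatter) from compound 3 to compound 4; the limit leaves it open whether they differ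

The compounds shown leave open what other groups on the amide-type nitrogen in the ring would do on either core, such as a methyl group, a longer chain or a chain ending in an amine. As far as these compounds go, it also remains open whether any such group on the core of compound 3 would give a value clear of the limit in this assay, which would allow a direct comparison of the two cores.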